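A Chloro for Fluoro Exchange in an Anticonvulsant Series

The compounds below may be only part of what the source reports. "The series", "measured", "known", "first", "only" and "open" are said of these compounds alone.

- compound 1 `O=C(/C=C/c1ccc(Br)cc1)NCCO`: 76 mg/kg
- compound 2 `O=C(/C=C/c1cccc(F)c1)NCCO`: 17 mg/kg

Both values come from a functional assay on the whole organism (strain Kunming) with Mus musculus as the target, in the maximal electroshock model (a lower number here means that less compound is needed, a higher number that more compound is needed for the effect), where each number is the dose that gives a half-maximal effect. Going by the values given here, of the two compounds tested so far, compound 2 stands lowest at 17 mg/kg, so it needs less compound for the effect. Compound 1 reads 76 mg/kg, and this gap lies beyond the usual scatter of repeated measurements.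

The next compound to be tested is compound 3 `O=C(/C=C/c1cccc(Cl)c1)NCCO`. It has chloro in place of fluoro on an aromatic carbon, and everything else stays the same as in compound 2: chloro in place of fluoro on an aromatic carbon.

Among the compounds with values here, no measured pair shows this exchange, so the data give no direct guide to its size. Compound 1 differs from compound 2 in more than one place, which makes it a poor guide as well. With a single atom exchanged, only a modest change seems likely in this assay. The expected result is a small rise in the number, a 1.5-fold higher number from compound 2 to compound 3 (0.17 log units; within the scatter), within the usual scatter. For compound 3 the estimated value is 25 mg/kg, with an expected range of 10 mg/kg to 60 mg/kg.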

Compound 3, dose for half-maximal effect: 25 mg/kg
Compound 3: middle estimate and measured number agree at the digits printed; the measured number falls inside the stated range.
By their numbers in this assay, from the lowest: compounds 2 and 3 (each within the scatter of the next); then compound 1.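

In this assay, chloro in place of fluoro on an aromatic carbon gives a 1.5-fold higher number from compound 2 to compound 3 (0.17 log units; within the scatter) and so leaves the two compounds inseparable by this measurement. Among the compounds shown, this is the only pair that differs in one place, which makes it the one direct reading of an exchange on this carbon, meta to a group of 8 heavy atoms: here one halogen can stand in for the other without a difference that rises above the scatter. Nothing measured alongside these numbers speaks to why the two halogens read alike.

Going by these compounds, two halogens at a single position make a narrow test, so whether a methoxy, a trifluoromethyl or an amine on the same carbon would also read alike remains open. Also open, on these data alone, is whether bromo on this carbon would read close to compound 2 and compound 3 or closer to compound 1 at 76 mg/kg, since compound 1 differs from both in more than one place and cannot settle the question by itself.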